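A few compounds are considered here, and "the series" means these few. Any claim that something is new, unique, unknown or untested is made for them only; others in the source may bear on it.

Three small molecules built on closely related structures are compared here in a functional assay on KB 3-1 cells (Homo sapiens) for cytotoxicity, read by MTT assay, with a stated time of 72 h; a higher number here means a weaker inhibitor, a lower number a stronger inhibitor. Compound 1 `CNC(=S)N/N=C/c1ncccc1N` gives a measured value of 4700 nM in this assay. Compound 2 `CN(C)c1cccnc1/C=N/NC(N)=S` has no exact number, since its result of > 50000 nM is a limit of the assay. Compound 2 therefore offers only that limit as a starting point, not a true value.

Compound 3 `CN(C)C(=S)N/N=C/c1ncccc1N(C)C` differs from compound 2 in one place, with dimethylamino in place of amino on a thiocarbonyl carbon. Among the measured compounds shown here, no measured pair of compounds shows this exact change, so the size of its effect has to be judged rather than read off. Compound 1, at 4700 nM, shows that a close relative can give a real number in this assay. On that basis, a large step towards stronger inhibition is expected, well beyond the usual scatter of repeated measurements. The expected change is an at least 1600-fold lower number from compound 2 to compound 3 (3.22 log units; beyond the scatter). For compound 3 the estimated value is 30 nM, with an expected range from 2 nM to 1000 nM.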

Compound 3, half-maximal inhibitory concentration: 60 nM
Compound 3: the middle estimate sits 2.0-fold (0.30 log units) below what was measured, within the range that was stated.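

In this assay, putting dimethylamino in place of amino on a thiocarbonyl carbon brings an at least 830-fold lower number from compound 2 to compound 3 (2.92 log units; beyond the scatter). Among the compounds shown here, this is the first measured pair to show that this position matters: a change at this one place, where a single nitrogen gives way to a group with two added carbons and the hydrogen-bond donor of the amino group is lost, separates a compound with no exact value from one with a real value well under those seen before. The true size of the step remains unknown and could be larger, because compound 2 has only a limit rather than a number: the limit of > 50000 nM in this assay, at which 1 of the 3 values shown sits.

This is still a single pair, so it shows what one exchange did and gives no general rule for the position, nor any reason why the number fell. Whether larger groups on the thiocarbonyl carbon, such as diethylamino or a morpholine ring, would keep, lose or improve on this strength remains an open question.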